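Working notes: triazole to tetrazole on the sulfur

The source may hold more compounds than are shown below. What is called first, only, known or untested is meant among the compounds shown, and "the series" means these compounds.

Among the measured compounds shown here, compound 3 `Cn1cnnc1SCC(=O)N/N=c1/scc(-c2ccccc2)n1-c1ccccc1` stands highest of the three numbers so far: in a functional assay on C6 cells (Rattus norvegicus) for cytotoxicity, read by MTT assay, with a stated time of 24 h, tested at 12 ug/mL (a lower number here means a stronger effect, a higher number a weaker effect of the compound at the concentration tested), compound 3 gives 79.6%. Compound 2 `Cn1nnnc1SCC(=O)N/N=c1/scc(-c2ccc([N+](=O)[O-])cc2)n1-c1ccccc1` lies nearest, since in this assay compound 2 gives 76.2%, a gap within the scatter, so no order between compound 2 and compound 3 is claimed. Compound 1 `Cn1nnnc1SCC(=O)N/N=c1/scc(-c2ccc(C#N)cc2)n1-c1ccccc1` lies furthest, and in this assay compound 1 gives 53.9%, a gap beyond the scatter. For the measured compounds named here, the only step between measured neighbours is a number 22.3 percentage points higher from compound 1 to compound 2 (beyond the scatter); it concerns the aryl substituent and nothing else.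

Compound 4 `Cn1nnnc1SCC(=O)N/N=c1/scc(-c2ccccc2)n1-c1ccccc1` differs from compound 3 in one place: 1-methyl-1H-tetrazol-5-yl in place of 4-methyl-4H-1,2,4-triazol-3-yl on a sulfur. Going by the values given here, no measured step covers this exchange. Compound 1 and compound 2 do carry the 1-methyl-1H-tetrazol-5-yl, but each differs from compound 4 at the aryl as well, so their values show only the span that tetrazole members have reached, not the effect of the heterocycle on its own. The step of a number 22.3 percentage points higher from compound 1 to compound 2 (beyond the scatter) sits at another place and gives no direction here. Among the compounds with values here, with no bearing step, the expected change for compound 4 is none beyond the scatter, and a number 7.6 percentage points lower from compound 3 to compound 4 (within the scatter) is the estimated step. Compound 4 is therefore estimated at 72%, with a range from 52% to 90%.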

Compound 4, a percentage reported as activity, at one concentration (the size of the read-out at that concentration, not a potency): 80.7%
Compound 4: middle estimate off by 8.7 percentage points, on the low side; the measured number falls inside the stated range.
By their numbers in this assay, from the lowest: compound 1; then compounds 2, 3 and 4 (each within the scatter of the next).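

The exchange at the sulfur, read in this assay, gives a number 1.1 percentage points higher from compound 3 to compound 4 (within the scatter), so with hydrogen on the aromatic carbon the 4-methyl-4H-1,2,4-triazol-3-yl and the 1-methyl-1H-tetrazol-5-yl cannot be told apart on this read-out. Compound 4 also supplies the hydrogen reference that the tetrazole members lacked: hydrogen in place of nitro gives a number 4.5 percentage points higher from compound 2 to compound 4 (within the scatter), whereas hydrogen in place of cyano gives a number 26.8 percentage points higher from compound 1 to compound 4 (beyond the scatter), so among these three tetrazole members, the cyano member alone stands apart from the hydrogen reference. No measurement at hand offers an explanation for either result.

As far as these compounds go, whether the heterocycle exchange stays this small when cyano occupies the aromatic carbon remains open, as the heterocycle has been compared at the sulfur only in the hydrogen pair, compound 3 and compound 4. Also open, from the compounds shown here alone, is how this read-out responds to an amine or a carboxylic acid on the aromatic carbon, or to a longer chain in place of the methyl on the heterocycle.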